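Adding a Second Methoxy Group to an Aminochalcone

The source may hold more compounds than are shown below. What is called first, only, known or untested is meant among the compounds shown, and "the series" means these compounds.

Measured compounds so far:
compound 1, `C=C(Br)C(=O)Nc1ccc(C(=O)/C=C/c2ccc(OC)c(OC)c2)cc1`, 770 nM
compound 2, `C=C(Br)C(=O)Nc1ccc(C(=O)/C=C/c2ccc(OC)c(OC)c2OC)cc1`, 510 nM
compound 3, `COc1cccc(/C=C/C(=O)c2ccc(N)cc2)c1`, 19000 nM

All three were tested in a functional assay on HeLa cells (Homo sapiens) for antiproliferative activity, with a stated time of 48 h; a lower number here means a stronger inhibitor, a higher number a weaker inhibitor. Compound 1 and compound 2 share one core, and the change between them is methoxy in place of hydrogen on an aromatic carbon. That change gave a 1.5-fold lower number from compound 1 to compound 2 (0.18 log units; within the scatter). Compound 3 has a different core, and the difference between the two cores is not broken down here; what the numbers show is that compound 3 gives a far higher value than either of the others in this assay.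

Compound 4, `COc1cc(/C=C/C(=O)c2ccc(N)cc2)cc(OC)c1`, has not yet been measured. It differs from compound 3 by methoxy in place of hydrogen on an aromatic carbon. Among the compounds with values here, this is the same kind of change as the one from compound 1 to compound 2, but not the same: in compound 2 the entering methoxy sits ortho to a large group, ortho to a methoxy group and meta to a methoxy group, whereas in compound 4 it sits meta to a large group and meta to a methoxy group, with nothing ortho to it.

The expectation rests on compound 1 and compound 2, where the step was a 1.5-fold lower number from compound 1 to compound 2 (0.18 log units; within the scatter), together with the value of compound 3, 19000 nM. The step from compound 3 to compound 4 is expected to be about a 1.6-fold lower number from compound 3 to compound 4 (0.20 log units; within the scatter), a small change beside the earlier one. Compound 4 is therefore estimated at 12000 nM, with a likely range from 4000 nM to 35000 nM.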

Compound 4, half-maximal inhibitory concentration: 7900 nM
For compound 4 the middle estimate is 1.5-fold (0.18 log units) above the measured one, within the range that was stated.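

In this assay, putting a methoxy group in place of a hydrogen on an aromatic carbon gave a 2.4-fold lower number from compound 3 to compound 4 (0.38 log units; beyond the scatter), a modest step but one that can be read on its own. Set beside the earlier case, this step cannot be told apart from it, so in this assay the change carries from one core to the other with a similar, small effect: the same change on two cores in this assay, a 1.5-fold lower number (0.18 log units; within the scatter) from compound 1 to compound 2 and a 2.4-fold lower number (0.38 log units; beyond the scatter) from compound 3 to compound 4, 1.6-fold (0.20 log units) apart, within the scatter of two such steps. Within the data shown here, this rests on only two pairs, however, and the methoxy enters at a different place in each, so the effect of the core cannot be separated from the effect of the position, and nothing here shows that the same step would hold on any further core.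

The compounds shown leave open whether a methoxy group placed on the core of compound 1 as it is placed in compound 4, meta to a large group and meta to a methoxy group, would give a step of the same size. They also leave open whether a different group at the position that changes between compound 3 and compound 4, such as a hydroxyl, an ethoxy group or a fluorine atom, would give a larger step, a smaller one or none.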